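Series notes: alkylation of the phenol ether on the shared core

A few compounds are considered here, and "the series" means these few. Any claim that something is new, unique, unknown or untested is made for them only; others in the source may bear on it.

Compound 3 `COc1cc(C(c2c(O)c3cc(Cl)ccc3oc2=O)c2c(O)c3cc(Cl)ccc3oc2=O)ccc1O` gives 83600 nM in an assay on isolated protein for inhibition of Maltase-glucoamylase (Homo sapiens) (a lower number here means a stronger inhibitor, a higher number a weaker inhibitor), the lowest of the three numbers, though its neighbours sit within the scatter: compound 2 `O=c1oc2ccc(Cl)cc2c(O)c1C(c1cccc(O)c1)c1c(O)c2cc(Cl)ccc2oc1=O` gives 84100 nM and compound 1 `COc1ccc(C(c2c(O)c3cc(Cl)ccc3oc2=O)c2c(O)c3cc(Cl)ccc3oc2=O)cc1O` gives 113000 nM. The steps of a 1.3-fold lower number from compound 1 to compound 2 (0.13 log units; within the scatter), a 1.4-fold lower number from compound 1 to compound 3 (0.13 log units; within the scatter) and a 1.0-fold lower number from compound 2 to compound 3 (0.00 log units; within the scatter) all stay within the scatter. Compound 4 `CCOc1cc(C(c2c(O)c3cc(Cl)ccc3oc2=O)c2c(O)c3cc(Cl)ccc3oc2=O)ccc1O` differs from compound 3 by methyl in place of hydrogen on a saturated chain carbon bound to an oxygen on an aromatic ring. Within the data shown here, no measured step alters this same position; the nearest comparisons, removal or relocation of a methoxy group, produced nothing beyond the scatter. The expected step is therefore none beyond the scatter, estimated as a 1.0-fold lower number from compound 3 to compound 4 (0.02 log units; within the scatter). Compound 4 is expected to give 80000 nM, within 40000 nM to 160000 nM.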

Compound 4, half-maximal inhibitory concentration: 57100 nM
For compound 4 the middle estimate is 1.4-fold (0.15 log units) above the measured one; low and high end bracket the measured number.
By their numbers in this assay, from the lowest: compounds 4, 3, 2 and 1 (each within the scatter of the next).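

Methyl in place of hydrogen on a saturated chain carbon bound to an oxygen on an aromatic ring, turning methoxy into ethoxy, is the first change tested at this position, and in this assay it stays within the scatter (a 1.5-fold lower number from compound 3 to compound 4 (0.17 log units; within the scatter)). Compound 4 also stays within the scatter of the other two compounds (a 1.5-fold lower number from compound 2 to compound 4 (0.17 log units; within the scatter); a 2.0-fold lower number from compound 1 to compound 4 (0.30 log units; within the scatter)), so this position tolerates the added methyl without a separable shift. No available evidence bears on this result.
Going by these compounds, whether a longer chain such as propoxy, or an amine carried on the ethoxy chain, would move the number beyond the scatter remains open.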